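A few compounds are considered here, and "the series" means these few. Any claim that something is new, unique, unknown or untested is made for them only; others in the source may bear on it.

Compound 1, `NC(=S)N/N=C/c1ccc2ccccc2n1`: 960 nM
Compound 2, `NC(=S)N/N=C/c1cc2cccnc2s1`: 6290 nM

Of the compounds shown here, two have been tested in a functional assay on HeLa cells (Homo sapiens) for antiproliferative activity, read by sulforhodamine B assay, with a stated time of 72 h; on this read-out higher numbers stand for weaker inhibition and lower numbers for stronger inhibition. Compound 1 gives 960 nM, the lowest of the two numbers, and compound 2 gives 6290 nM, a gap that lies beyond the usual scatter of repeated measurements. Among the measured compounds shown here, no pair of measured compounds differs in just one place, so there is no measured step to lean on.

Compound 3, `S=C(NCc1ccccc1)N/N=C/c1ccc2ccccc2n1`, has not yet been measured in this assay. It differs from compound 1 in one place: benzyl in place of hydrogen on an amide-type nitrogen. Since nothing measured here shows what that change does, the expectation rests on compound 1 alone. Compound 3 is expected to come out close to compound 1, with the step from a 1.6-fold lower number from compound 1 to compound 3 (0.20 log units; within the scatter) expected to be small, perhaps a modest move toward a lower number, but not clearly beyond the scatter. The estimate for compound 3 is 600 nM, within a range from 120 nM to 3000 nM.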

Compound 3, half-maximal inhibitory concentration: 62800 nM
Beside the measured number, compound 3's estimate is 100-fold (2.02 log units) below it; measured number outside the range, above it.
By their numbers in this assay, from the lowest: compound 1; then compound 2; then compound 3.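

In this assay, benzyl in place of hydrogen on the amide-type nitrogen, whose other neighbour is the thiocarbonyl carbon, gives a 65-fold higher number from compound 1 to compound 3 (1.82 log units; beyond the scatter) and so a large loss of inhibition. Among the compounds shown here, compound 1 and compound 2 both carry hydrogen on this nitrogen, so they could say nothing about it; this step is the first sign that this position does not accept every group. Nothing measured here explains why the loss is so large.

From the compounds shown here alone, it remains open whether the loss belongs to benzyl in particular or to any group at this position, which a small methyl group or a longer chain ending in an amine on the same nitrogen could help to separate. Going by these compounds, it is also open whether benzyl would cost as much on the core of compound 2.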